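Loss of the Chloro Group from Compound 2

A few compounds are considered here, and "the series" means these few. Any claim that something is new, unique, unknown or untested is made for them only; others in the source may bear on it.

Compound 2 `C/C(=N\NC(=S)Nc1ccccc1Cl)c1ccccn1` and compound 1 `C/C(=N\NC(=S)Nc1ccc(Cl)cc1)c1ccccn1` share one core and differ only in the placement of a chloro group on the six-membered aromatic ring of carbon only. Going by the values given here, in a functional assay on T98 cells (Homo sapiens) for cytotoxicity, read by MTT assay, with a stated time of 48 h (on this read-out higher numbers stand for weaker inhibition and lower numbers for stronger inhibition), compound 2 gives 1.1 nM, the lowest of the two numbers so far. In this assay compound 1 gives 5.9 nM, a higher number that lies beyond the scatter of the measurement, so compound 2 is the stronger of the two.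

Compound 3 `C/C(=N\NC(=S)Nc1ccccc1)c1ccccn1` has not yet been measured in this assay. Its change from compound 2 is hydrogen in place of chloro on an aromatic carbon. Among the compounds with values here, no step of this kind between two measured compounds is available, so the size of the effect cannot be read from the data. Compound 2 holds the lowest number, and the removal of its chloro group is expected to move the number upward, toward weaker inhibition, by a step that may be modest and could still fall within the scatter. For compound 3 the estimate in this assay is 4 nM, within a range from 1.5 nM to 15 nM. The step this expectation implies is a 3.6-fold higher number from compound 2 to compound 3 (0.56 log units; beyond the scatter).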

Compound 3, half-maximal inhibitory concentration: 6.8 nM
Estimate against measurement, compound 3: 1.7-fold (0.23 log units) below; measured number inside the range.
By their numbers in this assay, from the lowest: compound 2; then compounds 1 and 3 (each within the scatter of the next).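

In this assay, the change of chloro to hydrogen on an aromatic carbon ortho to a large group gives a 6.2-fold higher number from compound 2 to compound 3 (0.79 log units; beyond the scatter), so the low number of compound 2 depends on the chloro group at this place and not on the shared core alone. The same replacement made at the other chloro position, that of compound 1, gives a 1.2-fold higher number from compound 1 to compound 3 (0.06 log units; within the scatter), so compound 1 and compound 3 cannot be told apart here and the chloro group of compound 1 shows no measurable effect. Among these three compounds, then, the effect of chloro is tied to where it stands on the ring, and nothing available bears on why the two places behave differently.

Going by these compounds, what remains open is whether chloro itself is needed at the place ortho to a large group, or whether a fluoro, bromo, methyl or methoxy group there would hold the number of compound 2 equally well. It is also open whether this dependence on position carries over to other groups on the ring, since all of the comparisons shown rest on a single substituent and a single cell line.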